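Trifluoromethyl for Methyl in a 5-Lipoxygenase Inhibitor Pair

The compounds below may be only part of what the source reports. "The series", "measured", "known", "first", "only" and "open" are said of these compounds alone.

Compound 1, `CCCCC(Sc1ccc(OCCCOc2ccc(-c3ccccc3)cc2)cc1)C(=O)O`, gives 3500 nM in an assay for inhibition of Polyunsaturated fatty acid 5-lipoxygenase (Homo sapiens), read by HPLC, with a stated time of 10 min; on this read-out higher numbers stand for weaker inhibition and lower numbers for stronger inhibition.
Compound 2, `CCCCC(Sc1ccc(OCCCOc2cccc(C)c2)cc1)C(=O)O`, reaches only the limit of > 10000 nM in this assay.

Compound 2 thus stands at the edge of what the assay can report, as the limit of > 10000 nM in this assay, at which 1 of the 2 values shown sits, shows: for it there is a bound, not a number. Compound 3, `CCCCC(Sc1ccc(OCCCOc2cccc(C(F)(F)F)c2)cc1)C(=O)O`, differs from compound 2 in a single place: trifluoromethyl in place of methyl on an aromatic carbon. Among the measured compounds shown here, no measured pair of compounds shows this change, so its size in this assay cannot be read from the data at hand. With compound 2 already at a limit, the most plausible outcome is a step of no more than the usual scatter, in either direction. Compound 3 is therefore estimated at 12000 nM, with a range from 4000 nM to 40000 nM. The step this estimate implies is a step that the limit leaves unreadable from compound 2 to compound 3.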

Compound 3, half-maximal inhibitory concentration: 9800 nM
Estimate against measurement, compound 3: 1.2-fold (0.09 log units) above; the measured number falls inside the stated range.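

Replacing 3-methylphenyl with 3-(trifluoromethyl)phenyl gives a value that can be read as a number in this assay, where this end of the molecule previously offered only a bound. Compound 2 carries a limit, not a number: the limit of > 10000 nM in this assay, at which 1 of the 3 values shown sits.

The change can thus be stated only as a floor, an at least 1.0-fold lower number from compound 2 to compound 3 (0.00 log units; that floor lies within the scatter): the true step may be negligible or larger, and the data do not say which.

Still open, going by these compounds, is whether another group at this place, such as a chlorine atom, a methoxy group or an amine, would give a lower number than trifluoromethyl does. Also open, on these data alone, is whether the same swap would have a similar effect elsewhere on this ring.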